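The compounds below may be only part of what the source reports. "The series", "measured", "known", "first", "only" and "open" are said of these compounds alone.

Measured compounds:
compound 1, `CC(C)=CCOc1cc(Nc2ncccn2)ccc1Cl`: 2500 nM
compound 2, `CC(C)=CCOc1cc(Nc2ccccn2)ccc1C#N`: 290 nM

Of the compounds shown here, two have been measured in a functional assay on MT2 cells (Homo sapiens) for cytotoxicity; a higher number here means that more compound is tolerated, a lower number that less compound is tolerated. Compound 1 gives 2500 nM and stands with the higher of the two numbers. Compound 2 gives 290 nM in this assay, a lower number, and the gap between the two lies beyond the usual scatter of repeated measurements. The two structures differ in more than one place, so no single step can be read from them.

Compound 3, `CC(C)=CCOc1cc(Nc2nccc(N)n2)ccc1Cl`, has not yet been measured. It differs from compound 1 in one place: amino in place of hydrogen on an aromatic carbon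

Within the data shown here, nothing measured so far shows how an amino in place of hydrogen on an aromatic carbon of this core affects the read-out. Among the measured compounds shown here, with no measured step to rest on, the change is expected to move the number little in either direction, and the step of no change at the digits printed from compound 1 to compound 3 (within the scatter) is expected to stay within the scatter. Compound 3 is therefore estimated to give about 2500 nM in this assay, with a range from 900 nM to 7000 nM.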

Compound 3, half-maximal cytotoxic concentration: 500 nM
Compound 3: middle estimate off by 5.0-fold (0.70 log units), on the high side; measured number outside the range, below it.
By their numbers in this assay, from the lowest: compounds 2 and 3 (each within the scatter of the next); then compound 1.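

In this assay, among these compounds, the first step that can be read from a single change shows that this position on the pyrimidin-2-yl group is not indifferent to substitution: going from pyrimidin-2-yl to 4-aminopyrimidin-2-yl gives a 5.0-fold lower number from compound 1 to compound 3 (0.70 log units; beyond the scatter). The step is modest but beyond the scatter, so amino in place of hydrogen on this aromatic carbon, next to the ring nitrogen, goes with less compound being tolerated, something the earlier pair, which differs in more than one place, could not show. No measurement at hand explains this step, so it stands here as an observation only.

The compounds shown leave open whether another group at this same carbon, such as a hydroxyl, a methoxy or a dimethylamino, would go with a step of similar size and direction, or whether the amino itself is what matters. They also leave open whether an amino on another carbon of the same ring, or the same amino on a core carrying a nitrile in place of the chlorine, would shift the number to a similar extent.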